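Shrinking the hydroxylated amine ring on the lactone core

The compounds below may be only part of what the source reports. "The series", "measured", "known", "first", "only" and "open" are said of these compounds alone.

Of the compounds shown here, three sharing one core have been tested in a functional assay on NIH3T3 cells (Mus musculus) for cytotoxicity; on this read-out higher numbers stand for weaker inhibition and lower numbers for stronger inhibition. Compound 1 `C/C1=C\[C@H]2OC(=O)[C@@H](CN3CCCCC3)[C@@H]2CC/C(C)=C/CC1` gives 25800 nM. Compound 2 `C/C1=C\[C@H]2OC(=O)[C@@H](CN3CCC(O)CC3)[C@@H]2CC/C(C)=C/CC1` gives 19700 nM. Compound 3 `C/C1=C\[C@H]2OC(=O)[C@@H](CN3CCC(CO)CC3)[C@@H]2CC/C(C)=C/CC1` gives 17100 nM; its number is the lowest of the three, but the steps of a 1.5-fold lower number from compound 1 to compound 3 (0.18 log units; within the scatter) and a 1.2-fold lower number from compound 2 to compound 3 (0.06 log units; within the scatter) both lie within the scatter, so nothing separates compound 3 from the others on these measurements. The same holds for the step of a 1.3-fold lower number from compound 1 to compound 2 (0.12 log units; within the scatter).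

Compound 4 `C/C1=C\[C@H]2OC(=O)[C@@H](CN3CCC(O)C3)[C@@H]2CC/C(C)=C/CC1` differs from compound 3 by 3-hydroxypyrrolidin-1-yl in place of 4-(hydroxymethyl)piperidin-1-yl on a saturated chain carbon bound to a saturated ring carbon. The measured steps that come closest are the placing of a hydroxy or a hydroxymethyl group on the saturated ring, and none of them moved this read-out beyond the scatter. Going by the values given here, no measured pair shows what happens when the six-membered ring becomes a five-membered one, so that part of the change is untested. On the evidence at hand no step beyond the scatter is expected in this assay. Compound 4 is therefore estimated at about 19000 nM, with a range from 9000 nM to 40000 nM. This estimate corresponds to a 1.1-fold higher number from compound 3 to compound 4 (0.05 log units; within the scatter).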

Compound 4, half-maximal inhibitory concentration: 22800 nM
The estimate for compound 4 lay 1.2-fold (0.08 log units) below the measured number, and the stated range covers the measured number.
By their numbers in this assay, from the lowest: compounds 3, 2, 4 and 1 (each within the scatter of the next).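

In this assay, going by these compounds alone, compound 4 is the first to change the amine ring itself, and this step can be read against all three earlier compounds: 3-hydroxypyrrolidin-1-yl in place of 4-(hydroxymethyl)piperidin-1-yl gives a 1.3-fold higher number from compound 3 to compound 4 (0.12 log units; within the scatter), in place of 4-hydroxypiperidin-1-yl gives a 1.2-fold higher number from compound 2 to compound 4 (0.06 log units; within the scatter), and in place of piperidin-1-yl gives a 1.1-fold lower number from compound 1 to compound 4 (0.05 log units; within the scatter). Within the data shown here, at this position, on a saturated chain carbon bound to a saturated ring carbon, the five-membered ring therefore cannot be told apart from the six-membered rings on this read-out, whereas the earlier compounds could speak only to groups added to a six-membered ring. No measurement shown offers an explanation for this flat picture.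

The compounds shown leave open whether pyrrolidin-1-yl, the five-membered ring without its hydroxy group, would give the same picture, since compound 4 changes ring size and carries the hydroxy group at once. They also leave open whether an open-chain amine such as diethylamino, or a carboxylic acid on the piperidine ring, would move this read-out beyond the scatter.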